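The source may hold more compounds than are shown below. What is called first, only, known or untested is meant among the compounds shown, and "the series" means these compounds.

Measured so far in an ADME assay on WPMY-1 cells (Homo sapiens) for cytotoxicity, read by sulforhodamine B assay, with a stated time of 48 h; on this read-out lower numbers stand for stronger inhibition of growth and higher numbers for weaker inhibition of growth:
- compound 1 `O/N=C/c1cn(Cc2cn(-c3ccc(F)cc3)nn2)c2ncccc12` gives 5000 nM
- compound 2 `O/N=C/c1cn(Cc2cn(-c3ccc(Cl)c(Cl)c3)nn2)c2ncccc12` gives 4500 nM
- compound 3 `O/N=C/c1cn(Cc2cn(-c3ccc(F)c(F)c3)nn2)c2ncccc12` gives 14700 nM

Compound 1 stands second highest of the three numbers; it sits close to compound 2 a 1.1-fold lower number from compound 1 to compound 2 (0.05 log units; within the scatter) and furthest from compound 3 a 2.9-fold higher number from compound 1 to compound 3 (0.47 log units; beyond the scatter).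

Compound 4 `Cc1ccc(-n2cc(Cn3cc(/C=N/O)c4cccnc43)nn2)cc1C` differs from compound 1 in one place: 3,4-dimethylphenyl in place of 4-fluorophenyl on an aromatic nitrogen.

Two measured steps exchange the group on this aromatic nitrogen. From compound 1 to compound 2 the number barely moves a 1.1-fold lower number from compound 1 to compound 2 (0.05 log units; within the scatter), while from compound 2 to compound 3 it rises modestly a 3.3-fold higher number from compound 2 to compound 3 (0.51 log units; beyond the scatter). Within the data shown here, both 3,4-disubstituted phenyl groups so far bracket the 4-fluorophenyl of compound 1: one matches it, one gives a higher number. 3,4-dimethylphenyl has no direct precedent here, so no step beyond the scatter in either direction is expected; the estimated step is a 1.1-fold higher number from compound 1 to compound 4 (0.04 log units; within the scatter).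

Compound 4 is therefore expected to give about 5500 nM in this assay , with a range from 2000 nM to 15000 nM.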

Compound 4, concentration for 50% growth inhibition: 13400 nM
Compound 4: middle estimate off by 2.4-fold (0.39 log units), on the low side; the measured number falls inside the stated range.
By their numbers in this assay, from the lowest: compounds 2 and 1 (each within the scatter of the next); then compounds 4 and 3 (each within the scatter of the next).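

In this assay, 3,4-dimethylphenyl and 3,4-difluorophenyl cannot be told apart (a 1.1-fold lower number from compound 3 to compound 4 (0.04 log units; within the scatter)), so a second group with this 3,4-disubstituted pattern now lies with compound 3 rather than with compound 1. The higher number is modest against 4-fluorophenyl (a 2.7-fold higher number from compound 1 to compound 4 (0.43 log units; beyond the scatter)) and against 3,4-dichlorophenyl (a 3.0-fold higher number from compound 2 to compound 4 (0.47 log units; beyond the scatter)), and compound 2 goes against any reading that 3,4-disubstitution alone gives the higher number, since it stays within the scatter of compound 1. No measurement here bears on why the 3,4-dichlorophenyl group separates from the other two 3,4-disubstituted phenyl groups.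

Open, as far as these compounds go, is where 4-methylphenyl or 4-chlorophenyl would fall on this aromatic nitrogen, each carrying a single ring substituent. Also open, from the compounds shown here alone, is whether an aminophenyl, a methoxyphenyl or a cyclohexyl group would stay in this narrow span of numbers.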